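From 2-chlorophenyl to 3-methylphenyl on a shared core

The compounds below may be only part of what the source reports. "The series", "measured", "known", "first", "only" and "open" are said of these compounds alone.

In a physicochemical assay for lipophilicity (a higher number here means a more lipophilic compound, a lower number a more polar compound), compound 1 `CNC(=O)c1cc(C(=O)N[C@H]2CC[C@H](O)CC2)n([C@@H](C)c2ccc(Cl)cc2)n1` gives 3.7 and compound 2 `CNC(=O)c1cc(C(=O)N[C@H]2CC[C@H](O)CC2)n([C@@H](C)c2ccccc2)n1` gives 2.9 while compound 3 `CNC(=O)c1cc(C(=O)N[C@H]2CC[C@H](O)CC2)n([C@@H](C)c2ccccc2Cl)n1` gives 3.9 on the same scale. Compound 3 stands well above compound 2 but cannot be told apart from compound 1: the change from 4-chlorophenyl to 2-chlorophenyl amounts to a number 0.20 log units higher from compound 1 to compound 3 (within the scatter) and so separates nothing.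

The unmeasured compound 4 `CNC(=O)c1cc(C(=O)N[C@H]2CC[C@H](O)CC2)n([C@@H](C)c2cccc(C)c2)n1` has 3-methylphenyl in place of 2-chlorophenyl on a saturated chain carbon bound to an aromatic nitrogen and a saturated chain carbon.

Among the measured compounds shown here, no measured step involves a methyl group, so the best available guides are the steps that take a chloro group off or put one on. Hydrogen in place of chloro gave a number 0.80 log units lower from compound 1 to compound 2 (beyond the scatter) and chloro in place of hydrogen gave a number 1.00 log units higher from compound 2 to compound 3 (beyond the scatter) in the opposite direction. Both are modest, and they frame the likely span. Compound 4 is expected to fall inside that span, which makes a modest drop in this assay the most likely outcome. The estimated step is a number 0.40 log units lower from compound 3 to compound 4 (beyond the scatter) and it remains a judgement. In this assay compound 4 is estimated at 3.5 with an expected range from 3.1 to 3.9 for the eventual measurement.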

Compound 4, distribution coefficient: 3.4
Compound 4: the middle estimate sits 0.10 log units above what was measured, within the range that was stated.
By their numbers in this assay, from the lowest: compound 2; then compounds 4, 1 and 3 (each within the scatter of the next, the first and the last beyond it).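

In this assay, putting a methyl group on the ring gives a number 0.50 log units higher from compound 2 to compound 4 (beyond the scatter), so a chloro group is not the only substituent on this ring that separates a compound from the unsubstituted phenyl of compound 2. Exchanging the groups directly, 3-methylphenyl in place of 2-chlorophenyl on this saturated chain carbon gives a number 0.50 log units lower from compound 3 to compound 4 (beyond the scatter), while 3-methylphenyl in place of 4-chlorophenyl gives a number 0.30 log units lower from compound 1 to compound 4 (within the scatter). The same methyl compound can therefore be told apart from compound 3 but not from compound 1, even though compound 1 and compound 3 cannot be told apart from each other, so these small gaps do not give a firm ranking of the three substituted compounds.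

Nothing available explains why these groups give the numbers they do. The compounds shown leave open how 2-methylphenyl or 4-methylphenyl would compare with the matching chlorophenyl compounds, and what a ring carrying an amine or a carboxylic acid, or a longer chain such as propyl in place of the methyl, would read on the same scale.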